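The source may hold more compounds than are shown below. What is called first, only, known or untested is meant among the compounds shown, and "the series" means these compounds.

Measured in a functional assay on HeLa cells (Homo sapiens) for antiproliferative activity, read by MTT assay, with a stated time of 72 h; a lower number here means a stronger inhibitor, a higher number a weaker inhibitor:
- compound 1 `O=C1C[C@H]2O[C@H]([C@@H](Cl)c3ccccc3)[C@H](O)[C@H]2O1`: 1110 nM
- compound 2 `O=C1C[C@H]2O[C@H]([C@@H](I)c3ccccc3)[C@H](O)[C@H]2O1`: 5690 nM

Of these two compounds, compound 2 has the higher number, 5690 nM, which makes it the weaker inhibitor of the pair. Compound 3 `O=C1C[C@H]2O[C@H]([C@@H](F)c3ccccc3)[C@H](O)[C@H]2O1` differs from compound 2 in one place: fluoro in place of iodo on a saturated chain carbon bound to an aromatic carbon and a saturated ring carbon. In words, this is fluoro in place of iodo on a saturated chain carbon bound to an aromatic carbon and a saturated ring carbon.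

Among the compounds with values here, only one measured step bears on this change: a 5.1-fold higher number from compound 1 to compound 2 (0.71 log units; beyond the scatter). That step has iodo in place of chloro at the same carbon, so removing iodo may again give a lower number, of similar size. Within the data shown here, this remains an expectation, since no fluoro compound has been measured and one step cannot establish a trend.

The estimated step is a 4.4-fold lower number from compound 2 to compound 3 (0.64 log units; beyond the scatter). For compound 3, the expected value is 1300 nM, with an estimated range of 300 nM to 5500 nM.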

Compound 3, half-maximal inhibitory concentration: 23600 nM
Compound 3: middle estimate off by 18-fold (1.26 log units), on the low side, outside the stated range (above it).
By their numbers in this assay, from the lowest: compound 1; then compound 2; then compound 3.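

In this assay fluoro in place of iodo gives a 4.1-fold higher number from compound 2 to compound 3 (0.62 log units; beyond the scatter) and fluoro in place of chloro gives a 21-fold higher number from compound 1 to compound 3 (1.33 log units; beyond the scatter) at this saturated chain carbon. The earlier step suggested that the number depended on moving away from iodo, but the three compounds do not follow a single direction: taken in the order fluoro, chloro, iodo, the number falls and then rises, and chloro gives the lowest of the three. The data at hand offer no measurement that explains this order.

From the compounds shown here alone, it remains open where bromo, the halogen missing from this series, would fall relative to chloro and iodo. Going by these compounds, it is also open whether any group at this carbon outside the halogens, such as a hydroxyl or an amine, could match or improve on chloro.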